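This account rests on a few compounds, and the source may have more. Where it says the series, first, only, none or still open, it means among the compounds named here.

Within the data shown here, in a functional assay on MCF7 cells (Homo sapiens) for inhibition, read by sulforhodamine B assay (on this read-out higher numbers stand for weaker inhibition and lower numbers for stronger inhibition), compound 2 `COc1cccc(NC2=CC(=O)c3c(nc4n3[C@H]3OC[C@@H](O)[C@H]3OC4)C2=O)c1` gives 3830 nM, the only actual number so far. Compound 1 `Cc1ccc(NC2=CC(=O)c3c(nc4n3[C@H]3OC[C@@H](O)[C@H]3OC4)C2=O)cc1` is reported only as a limit, > 4000 nM. Among the measured compounds shown here, the single measured step, an at least 1.0-fold lower number from compound 1 to compound 2 (0.01 log units; that floor lies within the scatter), lies within the scatter, and it only exchanges one substituted phenyl group for another on the amine nitrogen.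

Compound 3 `CCCN(CCC)C1=CC(=O)c2c(nc3n2[C@H]2OC[C@@H](O)[C@H]2OC3)C1=O` brings a different kind of change, dipropylamino in place of (3-methoxyphenyl)amino on a double-bonded ring carbon. For the measured compounds named here, the aromatic ring and the hydrogen-bond donor on that nitrogen both go, and no measured compound shows what losing them does. The step of an at least 1.0-fold lower number from compound 1 to compound 2 (0.01 log units; that floor lies within the scatter) therefore serves only as weak guidance, and it gives no direction for the new change. Going by these compounds, with so little to go on, no shift beyond the scatter is predicted in this assay, though a wide range has to stay open. The expected step is a 1.1-fold lower number from compound 2 to compound 3 (0.04 log units; within the scatter). For compound 3 the estimated value is 3500 nM, with an expected range from 1000 nM to 10000 nM.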

Compound 3, half-maximal inhibitory concentration: > 16000 nM
Compound 3 was reported as a limit; the forecaster's own chance of this, stated with the estimate: 40%; middle value at least 4.5-fold (0.66 log units) from the limit.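

In this assay, this double-bonded ring carbon turns out to be sensitive to what its amine nitrogen carries: dipropylamino in place of (3-methoxyphenyl)amino gives an at least 4.1-fold higher number from compound 2 to compound 3 (0.62 log units; beyond the scatter). Among these compounds, this is the first step beyond the scatter, whereas the earlier exchange of one substituted phenyl group for another showed no readable change, and here a higher number means weaker inhibition, so compound 3 is the weaker of this pair. Compound 3 stands only as a limit, so the printed step is a floor rather than an exact size: the limit of > 16000 nM in this assay, at which 1 of the 3 values shown sits.

The step between compound 1 and compound 3 cannot be read, and the change removes the aromatic ring and the hydrogen-bond donor together, so the compounds shown do not separate the two losses. A propylamino group would keep the hydrogen on the nitrogen without the ring, and a methyl(phenyl)amino group would keep the ring without that hydrogen, so each would test one loss alone.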